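Replacing the methyltriazole with a dimethylaminoethyl triazole

The compounds below may be only part of what the source reports. "The series", "measured", "known", "first", "only" and "open" are said of these compounds alone.

Measured compounds:
compound 1 `CN(C)CCn1cnnc1-c1cc(Oc2ccc(NC(=O)N/N=C/c3cccc(Cl)c3Cl)cc2F)ccn1` gives 1090 nM
compound 2 `COc1ccc(/C=N/NC(=O)Nc2ccc(Oc3ccnc(-c4nncn4CCN(C)C)c3)c(F)c2)cc1O` gives > 100000 nM
compound 3 `Cn1ncnc1-c1cc(Oc2ccc(NC(=O)N/N=C/c3ccccc3)cc2F)ccn1` gives > 100000 nM

Three compounds sharing one core have been run in a functional assay on A549 cells (Homo sapiens) for cytotoxicity, read by MTT assay, with a stated time of 72 h; a higher number here means a weaker inhibitor, a lower number a stronger inhibitor. Compound 1 gives 1090 nM. For compound 2 the result is only a limit of the assay, > 100000 nM. For the measured compounds named here, the one step that compares two measured compounds in a single place is an at least 91-fold higher number from compound 1 to compound 2 (1.96 log units; beyond the scatter). Compound 3 likewise sits at a limit of the assay, > 100000 nM, so its standing among the numbers shown is known only as the limit of > 100000 nM in this assay, at which 2 of the 3 values shown sit.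

Compound 4 `CN(C)CCn1cnnc1-c1cc(Oc2ccc(NC(=O)N/N=C/c3ccccc3)cc2F)ccn1` differs from compound 3 in one place: 4-(2-(dimethylamino)ethyl)-4H-1,2,4-triazol-3-yl in place of 1-methyl-1H-1,2,4-triazol-5-yl on an aromatic carbon. No measured step touches this position; the only step shown, from compound 1 to compound 2, changes the aryl group on the hydrazone carbon instead, and both compounds with the dimethylaminoethyl triazole carry a substituted aryl there, whereas compound 4 carries the unsubstituted phenyl that compound 3 has. Because compound 3 is at a limit, the size of an at least 2.5-fold lower number from compound 3 to compound 4 (0.39 log units; beyond the scatter) is expected to be unresolved in direction and size. Compound 4 is therefore estimated at 40000 nM, within 4000 nM to 100000 nM, with a real chance that this assay again returns only a limit.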

Compound 4, half-maximal inhibitory concentration: 1860 nM
Compound 4: middle estimate off by 22-fold (1.33 log units), on the high side; measured number outside the range, below it.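

In this assay, with the unsubstituted phenyl held fixed, 4-(2-(dimethylamino)ethyl)-4H-1,2,4-triazol-3-yl in place of 1-methyl-1H-1,2,4-triazol-5-yl gives an at least 53-fold lower number from compound 3 to compound 4 (1.73 log units; beyond the scatter) and is the only step shown at this position, so the group on this aromatic carbon can decide whether the series reads as active at all. With the dimethylaminoethyl triazole in place, the aryl group on the carbon with a double bond to nitrogen need not be chlorinated: phenyl and 2,3-dichlorophenyl cannot be told apart, with a 1.7-fold higher number from compound 1 to compound 4 (0.23 log units; within the scatter) on that change. Among these three compounds only the 3-hydroxy-4-methoxyphenyl group stands apart, with an at least 53-fold lower number from compound 2 to compound 4 (1.73 log units; beyond the scatter) on going to phenyl, so the earlier drop traces to that group and not to a general need for the two chlorines.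

Still open, going by these compounds, is whether the terminal dimethylamine counts, or the altered attachment of the triazole, which changes in the same step, and a 2-hydroxyethyl or morpholinoethyl chain on the triazole would bear on that. The true size of the steps to compound 4 from compound 3 and compound 2 also stays open because both of those compounds rest on a limit: the limit of > 100000 nM in this assay, at which 2 of the 4 values shown sit.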